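The compounds below may be only part of what the source reports. "The series", "measured", "known", "first", "only" and "open" are said of these compounds alone.

Three analogues sharing one core were tested in a functional assay on B16-F10 cells (Mus musculus) for inhibition, read by MTT assay, with a stated time of 72 h; a higher number here means a weaker inhibitor, a lower number a stronger inhibitor. Compound 1 `CC(C)c1ccc(-c2nc(SCc3cn(CC(=O)NC(=O)Nc4ccccn4)nn3)nc(Nc3ccc(Cl)cc3)c2C#N)cc1` gives 860 nM, compound 2 `CC(C)c1ccc(-c2nc(SCc3cn(CC(=O)NC(=O)Nc4ccccn4)nn3)nc(Nc3cccc(C(F)(F)F)c3)c2C#N)cc1` gives 1700 nM, and compound 3 `COc1cc(-c2nc(SCc3cn(CC(=O)NC(=O)Nc4ccccn4)nn3)nc(Nc3cccc(C(F)(F)F)c3)c2C#N)cc(OC)c1OC` gives 24400 nM. Compound 1 differs from compound 2 by 4-chlorophenyl in place of 3-(trifluoromethyl)phenyl on a nitrogen on an aromatic ring, a change that brought a 2.0-fold lower number from compound 2 to compound 1 (0.30 log units; within the scatter). Compound 3 differs from compound 2 in its core by 3,4,5-trimethoxyphenyl in place of 4-isopropylphenyl on an aromatic carbon, which brought a 14-fold higher number from compound 2 to compound 3 (1.16 log units; beyond the scatter). Compound 4 `COc1cc(-c2nc(SCc3cn(CC(=O)NC(=O)Nc4ccccn4)nn3)nc(Nc3ccc(Cl)cc3)c2C#N)cc(OC)c1OC` carries the core of compound 3 and differs from it by 4-chlorophenyl in place of 3-(trifluoromethyl)phenyl on a nitrogen on an aromatic ring, the same change, at the same place, as that from compound 2 to compound 1. Among the compounds with values here, compound 4 is therefore expected to show a step like that earlier one, namely a 2.0-fold lower number from compound 3 to compound 4 (0.29 log units; within the scatter), resting on the single observed pair, compound 2 to compound 1 with a 2.0-fold lower number from compound 2 to compound 1 (0.30 log units; within the scatter). In this assay compound 4 is estimated at 12500 nM, between 5000 nM and 30000 nM.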

Compound 4, half-maximal inhibitory concentration: 1110 nM
For compound 4 the middle estimate is 11-fold (1.05 log units) above the measured one; measured number below the stated range.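

On the core of compound 3, 4-chlorophenyl in place of 3-(trifluoromethyl)phenyl gave a 22-fold lower number from compound 3 to compound 4 (1.34 log units; beyond the scatter), so in this assay this change did not carry over at the size seen on the other core: the same change on two cores in this assay, a 2.0-fold lower number (0.30 log units; within the scatter) from compound 2 to compound 1 and a 22-fold lower number (1.34 log units; beyond the scatter) from compound 3 to compound 4, 11-fold (1.05 log units) apart, beyond the scatter of two such steps. Likewise, 3,4,5-trimethoxyphenyl in place of 4-isopropylphenyl gave a 1.3-fold higher number from compound 1 to compound 4 (0.11 log units; within the scatter), so the effect of that change also differed with the group on the nitrogen: the same change on two cores in this assay, a 14-fold higher number (1.16 log units; beyond the scatter) from compound 2 to compound 3 and a 1.3-fold higher number (0.11 log units; within the scatter) from compound 1 to compound 4, 11-fold (1.05 log units) apart, beyond the scatter of two such steps. These four compounds show that the two changes do not add up independently here, but they do not show why, or how either change behaves on any other core.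

The compounds shown leave open whether a 4-methoxyphenyl group on the aromatic carbon would follow compound 3 or compound 1. They also leave open how a 4-fluorophenyl group on the nitrogen would behave on either core.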